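The source may report more compounds than this note shows. Statements on the series, on what has been measured and on what is new or still open speak of the compounds shown alone.

Measured in a functional assay on HL-60 cells (Homo sapiens) for inhibition, read by MTT assay, with a stated time of 72 h; a higher number here means a weaker inhibitor, a lower number a stronger inhibitor:
- Compound 1 `Cc1nc(-c2ccccc2)c(C(=O)N2CCN(c3cccc(C(N)=O)c3)CC2)o1`: 71 nM
- Compound 2 `Cc1nc(-c2ccccc2)c(C(=O)N2CCN(c3ccc(F)cc3)CC2)o1`: > 1000 nM, a limit of the assay and not a number
- Compound 3 `Cc1nc(-c2ccccc2)c(C(=O)N2CCN(c3ccccc3F)CC2)o1`: 147 nM

Of the two actual numbers, the higher belongs to compound 3 at 147 nM. Its nearest neighbour is separated by a 2.1-fold higher number from compound 1 to compound 3 (0.32 log units; beyond the scatter).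

Compound 4 `Cc1nc(-c2ccccc2)c(C(=O)N2CCN(c3cccc(C#N)c3)CC2)o1` carries 3-cyanophenyl in place of 2-fluorophenyl on an amine nitrogen in a ring.

Among the compounds with values here, no measured step makes this exact change. The closest comparison is compound 1, whose 3-carbamoylphenyl also replaces the 2-fluorophenyl, giving the modest 2.1-fold higher number from compound 1 to compound 3 (0.32 log units; beyond the scatter). The group on this nitrogen can matter much more, as the larger at least 14-fold higher number from compound 1 to compound 2 (1.14 log units; beyond the scatter) and an at least 6.8-fold lower number from compound 2 to compound 3 (0.83 log units; beyond the scatter) show, so the range is kept wide.

In this assay, no step beyond the scatter is expected, with any shift leaning towards a lower number. The expected step is a 1.3-fold lower number from compound 3 to compound 4 (0.13 log units; within the scatter). For compound 4 the estimated value is 110 nM, with an expected range of 40 nM to 350 nM.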

Compound 4, half-maximal inhibitory concentration: 39.6 nM
Beside the measured number, compound 4's estimate is 2.8-fold (0.44 log units) above it; the measured number lies below the stated range.
By their numbers in this assay, from the lowest: compounds 4 and 1 (each within the scatter of the next); then compound 3. At a limit, above all of these: compound 2.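

Replacing 2-fluorophenyl with 3-cyanophenyl gives a 3.7-fold lower number from compound 3 to compound 4 (0.57 log units; beyond the scatter), and replacing 4-fluorophenyl with it gives an at least 25-fold lower number from compound 2 to compound 4 (1.40 log units; beyond the scatter), so the aryl group on this amine nitrogen in a ring still has room for improvement over the fluorophenyl compounds. Exchanging carbamoyl for cyano on the aromatic carbon gives a 1.8-fold lower number from compound 1 to compound 4 (0.25 log units; within the scatter), so the nitrile and the primary amide cannot be told apart here, although 3-cyanophenyl has no hydrogen-bond donors. The second step is a bound and not an exact size, as compound 2 is a limit and not a number: the limit of > 1000 nM in this assay, at which 1 of the 4 values shown sits.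

Going by these compounds, how a carboxylic acid or an aminomethyl group would read on this phenyl ring stays open. The compounds shown also do not separate the identity of the nitrile from its place on the ring.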